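The source may hold more compounds than are shown below. What is called first, only, known or untested is meant among the compounds shown, and "the series" means these compounds.

Compound 1, `ClCc1ccc(Cn2cnc3c(Cl)ncnc32)cc1`, gives 1280 nM in a functional assay on M14 cells (Homo sapiens) for cytotoxicity, read by sulforhodamine B assay, with a stated time of 48 h; a lower number here means a stronger inhibitor of growth, a higher number a weaker inhibitor of growth. Compound 2, `Nc1nc(Cl)c2ncn(Cc3ccc(CCl)cc3)c2n1`, gives 14100 nM. Compound 3, `ClCc1ccccc1Cn1cnc2c(Cl)ncnc21`, gives 1950 nM.

Compound 1 and compound 2 differ in one place: amino in place of hydrogen on an aromatic carbon. That change brought an 11-fold higher number from compound 1 to compound 2 (1.04 log units; beyond the scatter). Compound 3 has the same atoms as compound 1, joined differently; the difference between the two cores is not broken down here. Compound 4, `Nc1nc(Cl)c2ncn(Cc3ccccc3CCl)c2n1`, is not yet measured. It stands to compound 3 as compound 2 stands to compound 1: amino in place of hydrogen on an aromatic carbon, at a place described in the same words, so it is the same change. Because that one earlier instance gave an 11-fold higher number from compound 1 to compound 2 (1.04 log units; beyond the scatter), compound 4 is expected to show an 11-fold higher number from compound 3 to compound 4 (1.03 log units; beyond the scatter). The value estimated for compound 4 is 21000 nM, likely between 7000 nM and 60000 nM.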

Compound 4, concentration for 50% growth inhibition: 5750 nM
For compound 4 the middle estimate is 3.7-fold (0.56 log units) above the measured one; measured number below the stated range.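

In this assay amino in place of hydrogen on an aromatic carbon gave a 2.9-fold higher number from compound 3 to compound 4 (0.47 log units; beyond the scatter) and so again a weaker inhibitor of growth. The direction of the change carried over from the core of compound 1 to the core of compound 3, but its size did not, and the gap between the two steps is larger than scatter alone would explain: the same change on two cores in this assay, an 11-fold higher number (1.04 log units; beyond the scatter) from compound 1 to compound 2 and a 2.9-fold higher number (0.47 log units; beyond the scatter) from compound 3 to compound 4, 3.7-fold (0.57 log units) apart, beyond the scatter of two such steps. Two pairs cannot show what sets the size of the step, or how large it would be on a further core.

The compounds shown carry only hydrogen or amino at this aromatic carbon. From the compounds shown here alone, how a methylamino group or a hydroxyl group there would compare remains open.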